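Thiomorpholin-4-yl for Piperidin-1-yl: What to Expect

This account rests on a few compounds, and the source may have more. Where it says the series, first, only, none or still open, it means among the compounds named here.

For the measured compounds named here, compound 1 `Cc1cccc(/C(N)=N/NC(=S)N2CCCCC2)n1` gives 36.6% in a functional assay on A-431 cells (Homo sapiens) for cytotoxicity, read by MTT assay, with a stated time of 72 h, tested at 3 uM (on this read-out lower numbers stand for less inhibition of growth and higher numbers for more inhibition of growth at the one concentration tested), the higher of the two numbers known here, while compound 2 `N/C(=N\NC(=S)N1CCCCC1)c1ccccn1` gives 27%; the step of a number 9.6 percentage points lower from compound 1 to compound 2 (within the scatter) lies within the scatter. Compound 3 `Cc1cccc(/C(N)=N/NC(=S)N2CCSCC2)n1` differs from compound 1 as follows: thiomorpholin-4-yl in place of piperidin-1-yl on a thiocarbonyl carbon. Going by the values given here, no measured step touches the ring on the thiocarbonyl carbon, so the two known compounds give no direction for this change; the only known step concerns a different place. Compound 3 is therefore expected to show a step of a number 1.6 percentage points lower from compound 1 to compound 3 (within the scatter), nothing beyond the scatter. The estimate for compound 3 is 35%, between 18% and 52%.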

Compound 3, percent growth inhibition at one concentration: 51.7%
Compound 3: middle estimate off by 16.7 percentage points, on the low side; low and high end bracket the measured number.
By their numbers in this assay, from the lowest: compounds 2 and 1 (each within the scatter of the next); then compound 3.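

The ring on the thiocarbonyl carbon is a place where a change can be seen in this assay: thiomorpholin-4-yl in place of piperidin-1-yl gives a number 15.1 percentage points higher from compound 1 to compound 3 (beyond the scatter). Both rings are six-membered, and the entering one carries a sulfur atom where the leaving one has a carbon. Nothing measured here accounts for this rise. Going by these compounds, whether morpholin-4-yl, with an oxygen atom in the ring, or piperazin-1-yl, with a second nitrogen, would behave like thiomorpholin-4-yl stays open. So does whether the same swap would raise the number on the core of compound 2, with hydrogen in place of methyl.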